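This account rests on a few compounds, and the source may have more. Where it says the series, first, only, none or still open, it means among the compounds named here.

Compound 1 `O=C(Nc1nnc(-c2ccc(Cl)cc2)s1)c1ccccc1I` gives > 5010 nM in a functional assay on the whole organism (integument) for inhibition, with Chilo suppressalis as the target, read by scintillation counting, with a stated time of 72 h; a higher number here means a weaker inhibitor, a lower number a stronger inhibitor. Compound 2 `O=C(Nc1nnc(-c2ccc(Cl)cc2)s1)c1ccccc1C(F)(F)F` gives > 16500 nM in this assay.

Each of these two values is a limit of this assay rather than a number, so compound 2 cannot be placed against compound 1. Among the measured compounds shown here, the single measured step, a step that the two limits leave unreadable from compound 1 to compound 2, stays unreadable because both ends sit at limits (the limit of > 16500 nM in this assay, at which 1 of the 2 values shown sits, (the limit of > 5010 nM in this assay, at which 1 of the 2 values shown sits)). Compound 3 `Cc1ccccc1C(=O)Nc1nnc(-c2ccc(Cl)cc2)s1` differs from compound 2 by methyl in place of trifluoromethyl on an aromatic carbon. No readable step bears on this change, so no shift beyond the scatter is expected. Compound 3 is estimated at 15000 nM, between 2000 nM and 60000 nM, most likely reported again as a limit. The expected step is an at least 1.1-fold lower number from compound 2 to compound 3 (0.04 log units; that floor lies within the scatter).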

Compound 3, half-maximal inhibitory concentration: 158 nM
Estimate against measurement, compound 3: 95-fold (1.98 log units) above; the measured number lies below the stated range.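

In this assay, among the compounds shown here, the position ortho to a large group turns out to respond strongly to the group it carries, and methyl is the first group here to give a readable value: the change to methyl gives an at least 100-fold lower number from compound 2 to compound 3 (2.01 log units; beyond the scatter), and from iodo it gives an at least 31-fold lower number from compound 1 to compound 3 (1.50 log units; beyond the scatter). The value of compound 2 is a limit of the assay: the limit of > 16500 nM in this assay, at which 1 of the 3 values shown sits. The value of compound 1 is also a limit of the assay: the limit of > 5010 nM in this assay, at which 1 of the 3 values shown sits.

The step between those two compounds cannot be read, which leaves iodo and trifluoromethyl unordered. As far as these compounds go, whether an ethyl chain, a methoxy group or a plain hydrogen at this place would match methyl remains open.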